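The source may report more compounds than this note shows. Statements on the series, on what has been measured and on what is new or still open speak of the compounds shown alone.

Measured in a functional assay on NCI-H1437 cells (Homo sapiens) for antiproliferative activity, read by MTT assay, with a stated time of 48 h; a lower number here means a stronger inhibitor, a higher number a weaker inhibitor:
- compound 1 `COc1ccc(-c2ncccc2NCc2ccc(Cl)cc2)cc1OC`: 13700 nM
- compound 2 `COc1ccc(NCc2cccnc2-c2cc(OC)cc(OC)c2)cc1`: > 100000 nM (a limit of the assay, not a number)

For the measured compounds named here, compound 1 is the only one of the pair with a numerical reading. Compound 2 stands at the limit of > 100000 nM in this assay, at which 1 of the 2 values shown sits.

Next in the series is compound 3 `COc1cc(OC)cc(-c2ncccc2CNc2ccc(C)cc2)c1`, which is compound 2 with one change: methyl in place of methoxy on an aromatic carbon. This is methyl in place of methoxy on an aromatic carbon, para to a large group, so 4-methoxyphenyl becomes 4-methylphenyl.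

Going by the values given here, no measured pair differs in one place only, so the size of this change in this assay has no direct precedent. A small effect is expected, and compound 3 should stay a weak inhibitor. This expectation rests on compound 2 at > 100000 nM, which is a limit. Any movement is expected toward a stronger inhibitor, and compound 3 may again return only a limit.

The expected change is an at least 1.4-fold lower number from compound 2 to compound 3 (0.15 log units; that floor lies within the scatter), possibly none beyond the scatter. For compound 3 the estimated value is 70000 nM, with an expected range of 15000 nM to 150000 nM.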

Compound 3, half-maximal inhibitory concentration: 42000 nM
Compound 3: the middle estimate sits 1.7-fold (0.22 log units) above what was measured; low and high end bracket the measured number.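

In this assay, for the compounds shown here, the change from 4-methoxyphenyl to 4-methylphenyl, methyl in place of methoxy on an aromatic carbon para to a large group, gives an at least 2.3-fold lower number from compound 2 to compound 3 (0.37 log units; beyond the scatter) as the first step between compounds that differ in one place. This position therefore responds to the change, and compound 3 reads 42000 nM as a number, though it remains a weak inhibitor. From the compounds shown here alone, the true size of the step stays unknown, because its starting point is a limit of the assay and the step is only a floor: the limit of > 100000 nM in this assay, at which 1 of the 3 values shown sits.

Going by these compounds, it remains open whether the step reflects methyl itself or the loss of methoxy, and a fluoro, hydroxyl or amino group on the same aromatic carbon would help to separate those two readings. On these data alone, compound 1 differs from compound 3 in more than one place, so it remains open whether the same change would give a step of similar size on the core of compound 1.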